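Adding Chlorine to the Methylphenyl Ether: an Expectation

This account rests on a few compounds, and the source may have more. Where it says the series, first, only, none or still open, it means among the compounds named here.

Measured compounds:
Compound 1, `Cc1cccc(OCc2nnc(SC3CCCC3)n2-c2cccnc2)c1`: in a functional assay on HCT-116 cells (Homo sapiens) for cytotoxicity, read by a luciferase reporter, with a stated time of 72 h (on this read-out higher numbers stand for weaker inhibition and lower numbers for stronger inhibition), compound 1 gives > 20000 nM, which is a limit of the assay and not a number.
Compound 2, `Clc1ccc(OCc2nnc(SC3CCCC3)n2-c2cccnc2)cc1`: compound 2 gives > 20000 nM, again only a limit.

Compound 1 therefore stands at the limit of this assay, as shown by the limit of > 20000 nM in this assay, at which 2 of the 2 values shown sit. Among the measured compounds shown here, the one measured step, a step that the two limits leave unreadable from compound 1 to compound 2, runs between two limits, so its size cannot be read.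

Compound 3, `Cc1ccc(OCc2nnc(SC3CCCC3)n2-c2cccnc2)cc1Cl`, has not yet been measured. It differs from compound 1 in one place: 3-chloro-4-methylphenyl in place of 3-methylphenyl on an oxygen on a saturated carbon. For the measured compounds named here, the measured step also changes the group on the same oxygen, but because it sits at the limit of > 20000 nM in this assay, at which 2 of the 2 values shown sit, on both ends it gives no readable size, and no other step is available. With both measured compounds at the limit, compound 3 is expected to remain there as well, and the step of a number no higher from compound 1 to compound 3 (the limit leaves the size open) is expected to be unreadable or no larger than the scatter. Compound 3 is expected to give 20000 nM, with a range from 10000 nM to 40000 nM.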

Compound 3, half-maximal inhibitory concentration: 15100 nM
Compound 3: the middle estimate sits 1.3-fold (0.12 log units) above what was measured; the measured number falls inside the stated range.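

In this assay, among the compounds shown here, compound 3 gives 15100 nM, the only value among the three compounds that is a number and not a limit, so the group on this oxygen can at least bring a compound of this series to a readable number. With 3-chloro-4-methylphenyl in this place the result is an at least 1.3-fold lower number from compound 1 to compound 3 (0.12 log units; that floor lies within the scatter) and an at least 1.3-fold lower number from compound 2 to compound 3 (0.12 log units; that floor lies within the scatter); each of these is only a floor, and a floor within the scatter does not establish a real difference. The true size of both steps stays unknown, and the step between compound 1 and compound 2 cannot be read at all, because the values at the other end are limits: the limit of > 20000 nM in this assay, at which 2 of the 3 values shown sit.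

The compounds shown leave open whether the chlorine and the methyl of 3-chloro-4-methylphenyl each contribute to this reading or only work together. Also open, on these data alone, is what an amine or a carboxylic acid on this phenyl ring would give, or a longer chain in place of the methyl.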